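A few compounds are considered here, and "the series" means these few. Any claim that something is new, unique, unknown or untested is made for them only; others in the source may bear on it.

Compounds measured: compound 1 `CN(Cc1ccc(C(F)(F)F)cc1)c1cc(C(=O)Nc2ccccc2)ncn1`, 258000 nM in an ADME assay on Vero cells (Chlorocebus sabaeus) for cytotoxicity, read by MTT assay; on this read-out higher numbers stand for weaker inhibition and lower numbers for stronger inhibition; compound 2 `CN(Cc1ccc(C#N)cc1)c1cc(C(=O)Nc2ccccc2)ncn1`, "not determined" (no result reported) in this assay.

Among the compounds with values here, compound 1 is the only compound with a number in this assay; compound 2, which carries a nitrile in place of the trifluoromethyl, has no reported result. Compound 1 sits at a high concentration, so in this assay it is a weak inhibitor of the cells. Compound 3 `CC(C)NC(=O)c1cc(N(C)Cc2ccc(C(F)(F)F)cc2)ncn1` has not yet been measured. It differs from compound 1 by isopropyl in place of phenyl on an amide-type nitrogen. Within the data shown here, with no pair of measured compounds differing in one place, nothing shows how such an exchange moves this read-out. The expectation for compound 3 is therefore a step that stays within the usual scatter, in no particular direction, a 1.0-fold lower number from compound 1 to compound 3 (0.01 log units; within the scatter). On that basis compound 3 is estimated at 250000 nM, with a range from 80000 nM to 700000 nM.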

Compound 3, half-maximal inhibitory concentration: 217000 nM
Compound 3: the middle estimate sits 1.2-fold (0.06 log units) above what was measured; the range from low to high includes it.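

In this assay, within the data shown here, isopropyl in place of phenyl on the amide-type nitrogen gives a 1.2-fold lower number from compound 1 to compound 3 (0.08 log units; within the scatter) and so provides the first readable step at this position. Although compound 3 lacks the six-membered aromatic ring of compound 1 and has fewer heavy atoms in this group, the two compounds cannot be told apart on this read-out. No supporting measurement is available to explain this result.

As far as these compounds go, it remains open whether a longer chain, a cyclohexyl group or a carboxylic acid on this nitrogen would give a number beyond the scatter of these two compounds. From the compounds shown here alone, it is also open whether the exchange of phenyl for isopropyl would read the same with a group other than trifluoromethyl on the benzyl ring.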